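Primary amine in place of pyrrolidine on the shared core

The source may hold more compounds than are shown below. What is called first, only, known or untested is meant among the compounds shown, and "the series" means these compounds.

Compound 1 `c1ccc(CNCC[C@@H]2CCC[C@@H](c3ccccc3)C2)cc1`: 1.8 nM; 2.4 nM (2 entries)
Compound 2 `NCC[C@@H]1CCC[C@H](c2ccccc2)C1`: 167 nM
Compound 3 `c1ccc([C@@H]2CCC[C@@H](CCN3CCCC3)C2)cc1`: 2 nM

Of the compounds shown here, three have been measured in an assay on membranes from brain for displacement of a labelled ligand from Sigma non-opioid intracellular receptor 1 (Cavia porcellus), read by scintillation counting, with a stated time of 120 min; a lower number here means a stronger inhibitor, a higher number a weaker inhibitor. Compound 3 gives 2 nM, the lowest number of the two single values; its nearest neighbour, compound 2, gives 167 nM, a gap far beyond the scatter. Compound 1 is recorded twice, (the several entries of compound 1 in this assay, 1.8 nM; 2.4 nM (2 entries)), both within the scatter of each other.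

Compound 4 `NCC[C@@H]1CCC[C@@H](c2ccccc2)C1` is not yet measured. It differs from compound 3 by amino in place of pyrrolidin-1-yl on a saturated chain carbon, two bonds along the chain from a saturated ring carbon. For the measured compounds named here, since no such step has been measured between two known compounds, a loss of potency is expected, because compound 2 gives 167 nM and is the other compound carrying an amino group. Compound 4 is estimated at 80 nM, with a range of 20 nM to 300 nM, a step of a 40-fold higher number from compound 3 to compound 4 (1.60 log units; beyond the scatter).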

Compound 4, inhibition constant: 43 nM
For compound 4 the middle estimate is 1.9-fold (0.27 log units) above the measured one; the measured number falls inside the stated range.
By their numbers in this assay, from the lowest: compound 3; then compound 4; then compound 2.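

Replacing pyrrolidin-1-yl with amino at this place on the chain costs a large amount of binding in this assay, with a 22-fold higher number from compound 3 to compound 4 (1.33 log units; beyond the scatter). Configuration matters too, but less, as a modest step shows, with a 3.9-fold lower number from compound 2 to compound 4 (0.59 log units; beyond the scatter). That smaller step comes from the stereocentre at a saturated ring carbon alone, because nothing else separates the two compounds: the fact that compounds 2 and 4 differ only in the configuration as drawn

Still open, going by these compounds, is how a piperidin-1-yl or dimethylamino group would fare on this chain. It is also unknown whether pyrrolidin-1-yl would give a similar step in the configuration of compound 2.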